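The source may report more compounds than this note shows. Statements on the series, on what has been measured and on what is new or still open speak of the compounds shown alone.

In a functional assay on a cell-free system (plasma, Homo sapiens) for inhibition, with Plasma (Rattus norvegicus) as the target (on this read-out lower numbers stand for stronger inhibition and higher numbers for weaker inhibition), compound 1 `O=c1cc(N2CCNCC2)c2ccccc2o1` gives 49000 nM, compound 2 `O=c1cc(N2CCNCC2)c2ccc(OCc3ccccc3)cc2o1` gives 16300 nM, and compound 3 `Cc1c(OCc2cccnc2)ccc2c(N3CCNCC3)cc(=O)oc12` gives 980 nM, the lowest number of the three. Compound 4 `O=c1cc(N2CCNCC2)c2ccc(OCc3cccnc3)cc2o1` differs from compound 3 by hydrogen in place of methyl on an aromatic carbon. Going by the values given here, the only measured step, a 3.0-fold lower number from compound 1 to compound 2 (0.48 log units; beyond the scatter), adds benzyloxy instead, so no measured step tests this change directly, and it offers only weak guidance. Compound 2 also lacks the methyl, though it carries benzyloxy rather than a (pyridin-3-yl)methoxy group, and stands at 16300 nM. A moderate rise is therefore expected, a 3.6-fold higher number from compound 3 to compound 4 (0.55 log units; beyond the scatter). The estimate for compound 4 is 3500 nM, with an expected range of 1000 nM to 13000 nM.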

Compound 4, half-maximal inhibitory concentration: 21300 nM
Beside the measured number, compound 4's estimate is 6.1-fold (0.78 log units) below it; measured number above the stated range.
By their numbers in this assay, from the lowest: compound 3; then compounds 2 and 4 (each within the scatter of the next); then compound 1.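

In this assay, hydrogen in place of methyl on the aromatic carbon ortho to the (pyridin-3-yl)methoxy group gives a 22-fold higher number from compound 3 to compound 4 (1.34 log units; beyond the scatter) as the step, so the low number of compound 3 depends heavily on this small methyl. Without the methyl, pyridin-3-yl in place of phenyl gives a 1.3-fold higher number from compound 2 to compound 4 (0.12 log units; within the scatter) as its step. Adding (pyridin-3-yl)methoxy to the bare core gives only a 2.3-fold lower number from compound 1 to compound 4 (0.36 log units; beyond the scatter) as its step, so this group achieves little alone.

From the compounds shown here alone, whether ethyl or methoxy at this position would keep the low number remains open, as does whether methyl would help compound 2 equally. No measurement here explains the size of the methyl step.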